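A few compounds are considered here, and "the series" means these few. Any claim that something is new, unique, unknown or untested is made for them only; others in the source may bear on it.

Measured in a functional assay on HT-29 cells (Homo sapiens) for inhibition, read by MTT assay, with a stated time of 48 h (on this read-out lower numbers stand for stronger inhibition and higher numbers for weaker inhibition), all three values being limits of the assay:

- compound 1 `COc1ccc(CSc2nnc(-c3cc(OC)c(OC)c(OC)c3)n2-c2ccc(OC)cc2)cc1`: > 60000 nM
- compound 2 `COc1ccc(C(=O)CSc2nnc(-c3cc(OC)c(OC)c(OC)c3)n2-c2ccc(OC)cc2)cc1`: > 60000 nM
- compound 3 `COc1ccc(-n2c(SCC(=O)c3ccc(OC)c(O)c3)nnc2-c2cc(OC)c(OC)c(OC)c2)cc1`: > 60000 nM

Compound 3 stands at the limit of > 60000 nM in this assay, at which 3 of the 3 values shown sit. No number is therefore available from which to gauge it against the others.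

Next in the series is compound 4 `COc1ccc(-n2c(SCC(=O)c3ccc4ccccc4c3)nnc2-c2cc(OC)c(OC)c(OC)c2)cc1`, with naphthalen-2-yl in place of 3-hydroxy-4-methoxyphenyl on a carbonyl carbon.

The measured steps that bear on this change all alter the same side chain: a step that the two limits leave unreadable from compound 1 to compound 2, a step that the two limits leave unreadable from compound 1 to compound 3 and a step that the two limits leave unreadable from compound 2 to compound 3. None has a readable size, so none gives a direction for the new change. A further reading at the limit in this assay is the likeliest outcome, although a measurable value cannot be ruled out on these data.

The expected change is an at least 1.2-fold lower number from compound 3 to compound 4 (0.07 log units; that floor lies within the scatter), with no direction readable beforehand.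

For compound 4 the estimate is 50000 nM, with an expected range of 5000 nM to 100000 nM.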

Compound 4, half-maximal inhibitory concentration: 53400 nM
Estimate against measurement, compound 4: 1.1-fold (0.03 log units) below; the range from low to high includes it.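

In this assay, among the compounds shown here, compound 4, with naphthalen-2-yl on the carbonyl carbon, gives 53400 nM, the only value so far that is a number and not a limit. The steps among compounds 1, 2 and 3 cannot be read, all three standing at a limit of the assay: the limit of > 60000 nM in this assay, at which 3 of the 4 values shown sit. As far as these compounds go, the change now reads as an at least 1.1-fold lower number from compound 3 to compound 4 (0.05 log units; that floor lies within the scatter), as an at least 1.1-fold lower number from compound 2 to compound 4 (0.05 log units; that floor lies within the scatter) and as an at least 1.1-fold lower number from compound 1 to compound 4 (0.05 log units; that floor lies within the scatter), so this position can give a measurable value, but the size of the gain remains unknown.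

Open, from the compounds shown here alone, is whether the second aromatic ring or the loss of the hydroxy and methoxy groups accounts for that value. Also open, going by these compounds, is whether a naphthalen-1-yl or a 4-aminophenyl group on the carbonyl carbon would give a lower number in this assay.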